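The compounds below may be only part of what the source reports. "The series", "measured", "known", "first", "only" and "open" are said of these compounds alone.

For the measured compounds named here, compound 1, `COc1ccc(C2CC(c3cccc4ccccc34)=NN2C(C)=O)cc1`, is the first of the measured compounds. In a functional assay on OVCAR cells (Homo sapiens) for cytotoxicity, read by sulforhodamine B assay, with a stated time of 48 h (a higher number here means a weaker inhibitor, a lower number a stronger inhibitor), compound 1 gives 6710 nM. Compound 2, `CC(=O)N1N=C(c2cccc3ccccc23)CC1/C=C/c1ccccc1`, differs from it in one place: 2-phenylethenyl in place of 4-methoxyphenyl on a saturated ring carbon. In this assay compound 2 gives 24000 nM, and the step recorded is a 3.6-fold higher number from compound 1 to compound 2 (0.55 log units; beyond the scatter), a weakening that lies beyond the usual scatter. Compound 3, `COc1ccc(C2CC(c3ccc4ccccc4c3)=NN2CC=O)cc1`, has the same atoms as compound 1 but joined differently; the difference between the two cores is not broken down here. In this assay compound 3 gives 5790 nM, which sits within the scatter of the value of compound 1 and beyond the scatter of the value of compound 2.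

Compound 4, `O=CCN1N=C(c2ccc3ccccc3c2)CC1/C=C/c1ccccc1`, has not yet been measured. It stands to compound 3 as compound 2 stands to compound 1: 2-phenylethenyl in place of 4-methoxyphenyl on a saturated ring carbon. The surroundings are not identical, since in compound 1 the neighbouring ring atom bears an acetyl group whereas in compound 3 it bears a formylmethyl group, so this is the same kind of change rather than the same change. Going by the values given here, with only one earlier example of this change and no counted difference between the cores, the expectation rests on that single step from compound 1 to compound 2. Compound 4 is therefore expected to fall by about a 3.6-fold higher number from compound 3 to compound 4 (0.56 log units; beyond the scatter) relative to compound 3, and its estimated value in this assay is 21000 nM, with a likely range from 9000 nM to 48000 nM.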

Compound 4, half-maximal inhibitory concentration: 18100 nM
Beside the measured number, compound 4's estimate is 1.2-fold (0.06 log units) above it, and the stated range covers the measured number.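

In this assay, replacing 4-methoxyphenyl with 2-phenylethenyl on the saturated ring carbon gives a 3.1-fold higher number from compound 3 to compound 4 (0.50 log units; beyond the scatter), so compound 4 is a weaker inhibitor than compound 3 by a margin beyond the scatter. Set beside the earlier example, the change weakens the compounds on both cores, and the two steps do not differ in size by more than the scatter allows: the same change on two cores in this assay, a 3.6-fold higher number (0.55 log units; beyond the scatter) from compound 1 to compound 2 and a 3.1-fold higher number (0.50 log units; beyond the scatter) from compound 3 to compound 4, 1.1-fold (0.06 log units) apart, within the scatter of two such steps This shows that the step carried over between these two cores, one bearing an acetyl group and the other a formylmethyl group on the neighbouring ring atom, but two cores are a small sample: it does not show that the step would hold on any other core, and it gives no reason for the weakening.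

Going by these compounds, what remains open is whether the double bond of the 2-phenylethenyl group or the loss of the 4-methoxyphenyl group accounts for the step, which a saturated phenylethyl chain or an unsubstituted phenyl group at the same ring carbon could begin to separate. On these data alone, it is also open whether the step would persist with an amine or a carboxylic acid in place of the formylmethyl group.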